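The compounds below may be only part of what the source reports. "The series", "measured", "known", "first", "only" and "open" are said of these compounds alone.

Compound 2 `COc1ccc(Cc2ccc3cc(NC(=O)c4ccc(O)c(CC=C(C)C)c4)c(=O)oc3c2C)cc1` gives 11100 nM in a functional assay on SK-BR-3 cells (Homo sapiens) for antiproliferative activity (on this read-out lower numbers stand for stronger inhibition and higher numbers for weaker inhibition), the lowest of the two numbers recorded so far. Its nearest neighbour, compound 1 `COc1ccc(Cc2ccc3cc(NC(=O)c4ccc(OC(C)=O)c(CC=C(C)C)c4)c(=O)oc3c2C)cc1`, gives 23500 nM in this assay, and the step of a 2.1-fold lower number from compound 1 to compound 2 (0.33 log units; beyond the scatter) came from hydrogen in place of acetyl on an oxygen on an aromatic ring. Compound 3 `CC(C)=CCc1cc(C(=O)Nc2cc3ccc(Cc4ccc(O)cc4)c(C)c3oc2=O)ccc1O` differs from compound 2 by hydrogen in place of methyl on an oxygen on an aromatic ring, which read one bond further out is methoxy to hydroxy, or 4-methoxybenzyl to 4-hydroxybenzyl. Among the compounds with values here, no measured pair shows exactly this change; the only step that bears on it, uncapping an aromatic oxygen, is a 2.1-fold lower number from compound 1 to compound 2 (0.33 log units; beyond the scatter), a modest move. Compound 3 is therefore expected to show a similarly modest step toward a lower number in this assay, a 1.5-fold lower number from compound 2 to compound 3 (0.17 log units; within the scatter), with a result within the scatter also plausible. Compound 3 is estimated at 7500 nM, with a likely range from 3000 nM to 20000 nM.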

Compound 3, half-maximal inhibitory concentration: 21500 nM
Estimate against measurement, compound 3: 2.9-fold (0.46 log units) below; measured number outside the range, above it.
By their numbers in this assay, from the lowest: compounds 2, 3 and 1 (each within the scatter of the next, the first and the last beyond it).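

In this assay the move from 4-methoxybenzyl to 4-hydroxybenzyl gives a 1.9-fold higher number from compound 2 to compound 3 (0.29 log units; within the scatter), so at this oxygen the methyl and the hydrogen cannot be told apart on this read-out. The earlier step, a 2.1-fold lower number from compound 1 to compound 2 (0.33 log units; beyond the scatter), lay beyond the scatter but concerned a different aromatic oxygen, the one carrying acetyl, and this result shows that it does not carry over: uncapping one aromatic oxygen does not predict what uncapping the other does. Nothing available here accounts for the difference between the two oxygens.

As far as these compounds go, it remains open how an amine or a carboxylic acid would read in place of the hydroxy of the 4-hydroxybenzyl group. From the compounds shown here alone, a longer chain such as ethoxy or propoxy in place of methoxy is equally open, as is whether any group here can take this series much below the values seen so far.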